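Halogens for a nitrile on the benzyl ether of compound 3

The compounds below may be only part of what the source reports. "The series", "measured", "known", "first", "only" and "open" are said of these compounds alone.

Measured compounds:
compound 1, `O=C(Nc1cccnc1)c1ccccc1OCc1ccccc1F`: 3500 nM
compound 2, `N#Cc1ccccc1COc1ccccc1C(=O)Nc1cccnc1`: 31800 nM
compound 3, `N#Cc1cccc(COc2ccccc2C(=O)Nc2cccnc2)c1`: 60700 nM

Compound 3 gives the highest number of the three in an assay on lysate for inhibition of phosphatidylcholine:ceramide cholinephosphotransferase 2 (Homo sapiens), read by HPLC, with stated times of 30 min and 2 h; a higher number here means a weaker inhibitor, a lower number a stronger inhibitor. Its nearest neighbour is compound 2, and the step of a 1.9-fold higher number from compound 2 to compound 3 (0.28 log units; within the scatter) lies within the scatter. Its furthest neighbour is compound 1, and the step of a 17-fold higher number from compound 1 to compound 3 (1.24 log units; beyond the scatter) is large.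

Compound 4, `O=C(Nc1cccnc1)c1ccccc1OCc1cc(F)ccc1Cl`, differs from compound 3 in one place: 2-chloro-5-fluorophenyl in place of 3-cyanophenyl on a saturated chain carbon bound to an oxygen on an aromatic ring. The measured step that bears most on this is a 9.1-fold higher number from compound 1 to compound 2 (0.96 log units; beyond the scatter), where cyano in place of fluoro on the same ring gave a clearly weaker inhibitor; compound 4 reverses that direction, trading the nitrile for two halogens. The step of a 17-fold higher number from compound 1 to compound 3 (1.24 log units; beyond the scatter) points the same way. A clear move toward a lower number in this assay is therefore expected, roughly the size of the step of a 13-fold lower number from compound 3 to compound 4 (1.13 log units; beyond the scatter).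

For compound 4 the estimate in this assay is 4500 nM, with a range from 1200 nM to 17000 nM.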

Compound 4, half-maximal inhibitory concentration: 740 nM
Beside the measured number, compound 4's estimate is 6.1-fold (0.78 log units) above it; the measured number lies below the stated range.
By their numbers in this assay, from the lowest: compound 4; then compound 1; then compounds 2 and 3 (each within the scatter of the next).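

In this assay the 2-chloro-5-fluorophenyl group is the best of the groups shown on the saturated chain carbon bound to an oxygen on an aromatic ring: replacing the cyanophenyl groups gives an 82-fold lower number from compound 3 to compound 4 (1.91 log units; beyond the scatter) and a 43-fold lower number from compound 2 to compound 4 (1.63 log units; beyond the scatter) as large steps, and replacing the 2-fluorophenyl group gives a 4.7-fold lower number from compound 1 to compound 4 (0.67 log units; beyond the scatter) as a modest step. The earlier compounds shown here showed only that 2-fluorophenyl gave a lower number than either cyanophenyl group, whereas compound 4 shows that this place allows a lower number still with both chlorine and fluorine on the ring. Nothing available here explains why this change lowers the number.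

The compounds shown leave open how much of the step belongs to the chlorine and how much to the fluorine. They also leave open whether a methoxy or trifluoromethyl group on this ring would lower the number further.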